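This account rests on a few compounds, and the source may have more. Where it says the series, first, only, none or still open, it means among the compounds named here.

Compound 1 (`Nc1ncnc2c1nnn2C[C@H]1CCC[C@H]1CO`) and compound 2 (`CC1(C)C(CO)CC1Cn1nnc2c(N)nc(N)nc21`) have both been tested in an ADME assay on L1210/0 cells (Mus musculus) for cytotoxicity, with a stated time of 48 h; on this read-out lower numbers stand for stronger inhibition and higher numbers for weaker inhibition. In this assay compound 1 gives > 200000 nM, which is a limit of the assay and not a number. In this assay compound 2 gives > 200000 nM, which is likewise only a limit. Compound 2 therefore stands at the limit of > 200000 nM in this assay, at which 2 of the 2 values shown sit, and no measured number fixes its place.

The next compound, compound 3 (`CC1(C)C(CO)CC1Cn1nnc2c(Cl)nc(N)nc21`), differs from compound 2 in one place: chloro in place of amino on an aromatic carbon. It carries chloro in place of amino on an aromatic carbon, on a six-membered aromatic ring with 2 nitrogen, next to the ring nitrogen. Among the measured compounds shown here, no measured step between two compounds offers a guide to the size of this change in this assay. A small shift toward stronger inhibition is expected, and a result that again reaches only the limit would fit as well. The expected change is an at least 1.6-fold lower number from compound 2 to compound 3 (0.22 log units; that floor lies within the scatter), and this figure is only an estimate. For compound 3 the expected value is 120000 nM, with an estimated range of 30000 nM to 200000 nM.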

Compound 3, half-maximal inhibitory concentration: > 200000 nM
Compound 3 was reported as a limit; the forecaster's own chance of this, stated with the estimate: 60%; middle value at least 1.6-fold (0.22 log units) from the limit.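

In this assay compound 3 gives > 200000 nM, which is a limit of the assay and not a number. Compound 2 also stands at a limit, so no step can be read between compound 2 and compound 3: the limit of > 200000 nM in this assay, at which 3 of the 3 values shown sit.

The compounds shown leave open whether chloro in place of amino on an aromatic carbon changes the value in this assay at all, and by how much.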